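Adding a second chloro to compound 2

This account rests on a few compounds, and the source may have more. Where it says the series, first, only, none or still open, it means among the compounds named here.

In a functional assay (mitochondria, liver) with Rattus norvegicus as the target (on this read-out higher numbers stand for weaker inhibition and lower numbers for stronger inhibition), compound 1 (`CC(C)(C)c1ccc(S(=O)(=O)CS(=O)(=O)C(F)(F)F)cc1`) gives 2800000 nM and compound 2 (`O=S(=O)(CS(=O)(=O)C(F)(F)F)c1ccc(Cl)cc1`) gives 4000000 nM, which leaves compound 2 level with compound 1 within the scatter. Compound 3 (`O=S(=O)(CS(=O)(=O)C(F)(F)F)c1ccc(Cl)c(Cl)c1`) carries chloro in place of hydrogen on an aromatic carbon, ortho to a chloro group and meta to a large group (chloro in place of hydrogen on an aromatic carbon). Among the compounds with values here, the only measured step (a 1.4-fold higher number from compound 1 to compound 2 (0.15 log units; within the scatter)) exchanges tert-butyl for chloro at another place and stays within the scatter, so no step beyond the scatter is expected in this assay here. The expected step is small (a 1.3-fold lower number from compound 2 to compound 3 (0.12 log units; within the scatter)). The estimated value for compound 3 is 3000000 nM (1200000 nM to 6000000 nM).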

Compound 3, half-maximal inhibitory concentration in the Rattus norvegicus assay: 5400000 nM
Compound 3: middle estimate off by 1.8-fold (0.26 log units), on the low side, and the stated range covers the measured number.
By their numbers in the Rattus norvegicus assay, from the lowest: compounds 1, 2 and 3 (each within the scatter of the next).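

In the Rattus norvegicus assay, adding a chloro in place of hydrogen, ortho to a chloro group, gives a 1.4-fold higher number from compound 2 to compound 3 (0.13 log units; within the scatter), so this position takes the extra atom without a step beyond the scatter. The same change does register in a physicochemical assay for lipophilicity, read by HPLC (a lower number here means a more polar compound, a higher number a more lipophilic compound), where compound 2 gives 1.9 and compound 3 gives 1, and compound 3 reads as the more polar of the pair: the measured partition coefficient of compound 2, 1.9, and of compound 3, 1, a number 0.90 log units lower (beyond the scatter)

From the compounds shown here alone, whether an amine or a carboxylic acid at this position would move the number in the Rattus norvegicus assay beyond the scatter stays open. A single pair also cannot tell whether inhibition follows the reading in the physicochemical assay at all.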